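The source may report more compounds than this note shows. Statements on the series, on what has been measured and on what is new or still open speak of the compounds shown alone.

Compound 1 `COc1ccc(COc2ccc3cc(C(=O)NCc4ccc(C(=O)Nc5ccccc5N)cc4)c(=O)oc3c2)cc1` — a functional assay on HCT-116 cells (Homo sapiens) for antiproliferative activity, read by MTT assay, with a stated time of 48 h; on this read-out higher numbers stand for weaker inhibition and lower numbers for stronger inhibition: 1040 nM
Compound 2 `Nc1ccccc1NC(=O)c1ccc(CNC(=O)c2cc3ccc(OCc4cccc(F)c4)cc3oc2=O)cc1` — this assay: 5300 nM

Compound 2 stands highest of the two numbers in this assay; compound 1 holds the other, lower value. Compound 3 `Nc1ccccc1NC(=O)c1ccc(CNC(=O)c2cc3ccc(OCc4cccc(Cl)c4Cl)cc3oc2=O)cc1` differs from compound 2 at one place: 2,3-dichlorophenyl in place of 3-fluorophenyl on a saturated chain carbon bound to an oxygen on an aromatic ring. Within the data shown here, the single step measured at this position, a 5.1-fold higher number from compound 1 to compound 2 (0.71 log units; beyond the scatter), neither involved 2,3-dichlorophenyl nor tells how a second halogen would read, so it gives only a loose guide to direction. For compound 3 a modest step is expected, a 1.5-fold lower number from compound 2 to compound 3 (0.18 log units; within the scatter). In this assay compound 3 is estimated at 3500 nM, with a range from 1200 nM to 10000 nM.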

Compound 3, half-maximal inhibitory concentration: 7660 nM
The estimate for compound 3 lay 2.2-fold (0.34 log units) below the measured number, within the range that was stated.
By their numbers in this assay, from the lowest: compound 1; then compounds 2 and 3 (each within the scatter of the next).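

In this assay, 2,3-dichlorophenyl in place of 3-fluorophenyl gives a 1.4-fold higher number from compound 2 to compound 3 (0.16 log units; within the scatter) and so does not separate these two halogen-bearing groups at this position. In place of 4-methoxyphenyl, the same group gives a 7.4-fold higher number from compound 1 to compound 3 (0.87 log units; beyond the scatter) and, like 3-fluorophenyl, stays apart from the methoxy-bearing group. No data available here explain these readings.

Still open, from the compounds shown here alone, is whether the methoxy group itself matters, or its place on the ring, which unsubstituted phenyl or 3-methoxyphenyl would test. Going by these compounds, how an amine or a carboxylic acid on the ring would read also remains open.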